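The source may hold more compounds than are shown below. What is called first, only, known or untested is meant among the compounds shown, and "the series" means these compounds.

Compound 1, `CCc1cc(C(C)=O)c(O)cc1OCCCCCCC#N`: in an assay on isolated protein for binding affinity to leukotriene B4 receptor 1 (Homo sapiens), tested at 1 uM (a lower number here means less inhibition, a higher number more inhibition at the concentration tested (going by the name of the read-out)), compound 1 gives 73%.
Compound 2, `C=CCc1cc(C(C)=O)c(O)cc1OCCCCCCC#N`: in this assay compound 2 gives 63%.
Compound 3, `C=CCc1cc(C(C)=O)c(O)cc1OCc1ccc(C#N)cc1`: in this assay compound 3 gives 28%.

Compound 2 and compound 1 share one core and differ in a single spot: methyl in place of vinyl on a saturated chain carbon bound to an aromatic carbon. The step that goes with this change is a number 10 percentage points higher from compound 2 to compound 1 (within the scatter), so the two numbers cannot be told apart by this kind of measurement.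

Compound 3 carries a different core; the difference between its core and the core of compound 2 is not broken down here. Compound 3 is the lowest of the three measured compounds, standing beyond the scatter from both compound 2 and compound 1.

Compound 4, `CCc1cc(C(C)=O)c(O)cc1OCc1ccc(C#N)cc1`, has not been measured. It is built from compound 3 by methyl in place of vinyl on a saturated chain carbon bound to an aromatic carbon, which is the same change that leads from compound 2 to compound 1, made at the same kind of spot. Since that earlier change produced only a number 10 percentage points higher from compound 2 to compound 1 (within the scatter), the step from compound 3 to compound 4 is expected to be of the same small size, a number 8 percentage points higher from compound 3 to compound 4 (within the scatter), a move that stays inside the usual scatter. On that basis compound 4 is estimated to give 36% in this assay, with a likely range from 16% to 56%, because compound 3 gives 28% and the change is expected to shift it only slightly.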

Compound 4, a percentage reported as inhibition, at one concentration (the size of the read-out at that concentration, not a potency): 11%
Beside the measured number, compound 4's estimate is 25 percentage points above it; the whole stated range lies above it.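

In this assay, swapping allyl for ethyl, which puts methyl in place of vinyl on a saturated chain carbon bound to an aromatic carbon, gives a number 17 percentage points lower from compound 3 to compound 4 (beyond the scatter), and the same change does not act alike on the two cores: the same change on two cores in this assay, a number 10 percentage points higher (within the scatter) from compound 2 to compound 1 and a number 17 percentage points lower (beyond the scatter) from compound 3 to compound 4, 27 percentage points apart, beyond the scatter of two such steps

So in this small series, the step seen on the core of compound 2 was no reliable guide to the step on the core of compound 3, and a change that made no readable difference on one core made a readable one on the other. This does not show which part of the two cores is responsible, since the difference between them is not broken down here, and two pairs of compounds cannot give a general rule for any further core.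

The compounds shown leave open what a propyl group or a longer chain in place of the ethyl would do in this assay on either core, which would show whether the contrast holds beyond this one swap. They also leave open whether the two cores would still part ways if a carboxylic acid stood in place of the nitrile.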